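Cytotoxicity notes: a cyclopentylsulfamoyl variant of compound 1

The compounds below may be only part of what the source reports. "The series", "measured", "known", "first", "only" and "open" are said of these compounds alone.

Measured so far in a functional assay on MT4 cells (Homo sapiens) for cytotoxicity, read by CellTiter-Glo, with a stated time of 5 days; on this read-out lower numbers stand for an effect already at smaller amounts and higher numbers for an effect only at larger amounts of compound:
- compound 1, `Cc1noc(C)c1-c1cc(-c2c(C)noc2C)c2nc(C3CC3)[nH]c2c1`, gives 80 nM
- compound 2, `Cc1noc(C)c1-c1cc(-c2c(C)noc2C)c2cccnc2c1`, gives 897 nM
- compound 3, `Cc1cc(-c2ccc(C)c(S(=O)(=O)NC3CCCC3)c2)cnn1`, gives 3760 nM

Compound 1 stands at the lowest number of the three. Compound 2 lies at a higher number, beyond the usual scatter, and compound 3 further still, also beyond the scatter. For the measured compounds named here, the two carry different cores from compound 1, so neither pair amounts to a single-site step, and no such step exists among the measured compounds.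

Compound 4, `Cc1noc(C)c1-c1cc(S(=O)(=O)NC2CCCC2)c2nc(C3CC3)[nH]c2c1`, keeps the core of compound 1 and differs from it in one place: cyclopentylsulfamoyl in place of 3,5-dimethyl-1,2-oxazol-4-yl on an aromatic carbon. Going by the values given here, compound 3 also carries a cyclopentylsulfamoyl group, but on an unrelated core, so its value shows only that this group is compatible with a high number there. Among the compounds with values here, with no measured step to lean on, a moderate move toward a higher number is expected, a 3.8-fold higher number from compound 1 to compound 4 (0.57 log units; beyond the scatter), and a result within the scatter cannot be ruled out. Compound 4 is therefore estimated at 300 nM, with a range from 90 nM to 1500 nM.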

Compound 4, half-maximal effective concentration: 290 nM
Estimate against measurement, compound 4: 1.0-fold (0.01 log units) above; the measured number falls inside the stated range.
By their numbers in this assay, from the lowest: compound 1; then compound 4; then compound 2; then compound 3.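

In this assay, a 3.6-fold higher number from compound 1 to compound 4 (0.56 log units; beyond the scatter) gives the series its first single-site reading: at this aromatic carbon, ortho to a fused ring, the change to cyclopentylsulfamoyl gives a modest step beyond the scatter. The 3,5-dimethyl-1,2-oxazol-4-yl group at this place is therefore not required for an effect in this assay, as compound 4, which retains the other such group, still gives 290 nM. Nothing at hand explains the step, and it cannot be divided between the group that leaves and the group that enters.

From the compounds shown here alone, it remains open whether an amine or a carboxylic acid at this carbon would give a number nearer to that of compound 1 or further from it. Also open, going by these compounds, is whether the cyclopentyl ring matters, as a methylsulfamoyl group or a longer open chain on the sulfonamide nitrogen would show.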